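The source may hold more compounds than are shown below. What is called first, only, known or untested is meant among the compounds shown, and "the series" means these compounds.

Three compounds have been measured in a functional assay on M21 cells (Homo sapiens) for antiproliferative activity, read by sulforhodamine B assay, with a stated time of 48 h; on this read-out higher numbers stand for weaker inhibition and lower numbers for stronger inhibition:

Compound 1 `O=C1NCCN1c1ccc(S(=O)(=O)Nc2cccc(Br)c2)cc1` gives 59 nM.
Compound 2 `O=C1NCCN1c1ccc(S(=O)(=O)Nc2ccc(F)c(F)c2)cc1` gives 220 nM.
Compound 3 `O=C1NCCN1c1ccc(S(=O)(=O)Nc2cccc(Oc3ccccc3)c2)cc1` gives 83 nM.

All three share one core and differ only in the group carried on the sulfonamide nitrogen. Compound 3 holds the second highest of the three numbers in this assay; its number and that of compound 1 lie within the scatter of each other, while compound 2 stands beyond the scatter with the higher number. Compound 4 `O=C1NCCN1c1ccc(S(=O)(=O)Nc2cccc(Cl)c2)cc1` is the next step from compound 3: chloro in place of phenoxy on an aromatic carbon. Among the measured compounds shown here, no measured step makes exactly this change. The nearest is a 1.4-fold higher number from compound 1 to compound 3 (0.15 log units; within the scatter), which lay within the scatter. For the measured compounds named here, the only step beyond the scatter, a 3.7-fold higher number from compound 1 to compound 2 (0.57 log units; beyond the scatter), swapped in two fluorines at other positions and says little about a single halogen here. Since bromo in compound 1 and chloro in compound 4 are both single halogens on the same aromatic carbon, compound 4 is expected to land close to compound 1 and compound 3, with no step beyond the scatter: a 1.2-fold lower number from compound 3 to compound 4 (0.07 log units; within the scatter) is the expected step. Compound 4 is estimated at 70 nM, within a range of 30 nM to 160 nM.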

Compound 4, half-maximal inhibitory concentration: 25 nM
Compound 4: middle estimate off by 2.8-fold (0.45 log units), on the high side; measured number below the stated range.
By their numbers in this assay, from the lowest: compound 4; then compounds 1 and 3 (each within the scatter of the next); then compound 2.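

In this assay, this aromatic carbon proves sensitive to its group: the step of a 3.3-fold lower number from compound 3 to compound 4 (0.52 log units; beyond the scatter) passes the scatter, which the earlier change from bromo to phenoxy did not. Even two single halogens are told apart here, as chloro in place of bromo gives a 2.4-fold lower number from compound 1 to compound 4 (0.37 log units; beyond the scatter) and so goes beyond the scatter. The 3-chlorophenyl group in place of 3,4-difluorophenyl gives the largest of these steps, an 8.8-fold lower number from compound 2 to compound 4 (0.94 log units; beyond the scatter), and compound 4 now has the lowest number of the four.

Nothing available here explains these differences. Also open, going by these compounds, is how fluoro, methoxy, an amine or a carboxylic acid on this same aromatic carbon would compare with chloro.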